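Trading the morpholinyl triazene for a cyano triazene

The compounds below may be only part of what the source reports. "The series", "measured", "known", "first", "only" and "open" are said of these compounds alone.

Compound 1 `CCOC(=O)c1c(N=C=S)sc(-c2ccccc2)c1C` gives 3500 nM in an in vitro functional assay on HEK293 cells for antagonist activity at metabotropic glutamate receptor 6 (Homo sapiens), read by reporter gene assay, luminescence and calcium flux, tested at 10 uM; a higher number here means a weaker inhibitor, a lower number a stronger inhibitor. Compound 2 `CCOC(=O)c1c(N=NN2CCOCC2)sc(-c2ccccc2)c1C` stands highest of the two numbers in this assay at 54000 nM, with a 15-fold higher number from compound 1 to compound 2 (1.19 log units; beyond the scatter). Compound 3 `CCOC(=O)c1c(N=NC#N)sc(-c2ccccc2)c1C` differs from compound 2 by cyano in place of morpholin-4-yl on a double-bonded nitrogen. For the measured compounds named here, no measured step changes exactly this part, but the only step on this side of the core, from the small group of compound 1 to the large group of compound 2, was large; since compound 3 carries a smaller group again, a moderate step downward is expected, as a 3.6-fold lower number from compound 2 to compound 3 (0.56 log units; beyond the scatter). Compound 3 is therefore estimated at 15000 nM, within 3000 nM to 60000 nM.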

Compound 3, half-maximal inhibitory concentration: 21000 nM
Estimate against measurement, compound 3: 1.4-fold (0.15 log units) below; low and high end bracket the measured number.
By their numbers in this assay, from the lowest: compound 1; then compound 3; then compound 2.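

In this assay, cyano in place of morpholin-4-yl gives a 2.6-fold lower number from compound 2 to compound 3 (0.41 log units; beyond the scatter) and so recovers only part of the loss seen with the morpholinyl triazene. The smaller triazene still does not match the isothiocyanate, with a 6.0-fold higher number from compound 1 to compound 3 (0.78 log units; beyond the scatter), so shrinking the group on the double-bonded nitrogen does not by itself return the number to that of compound 1. Nothing shown here explains either step. Open, on these data alone, is whether the triazene link is needed at all, and how an amine or a carboxylic acid on the aromatic carbon would compare.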